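The source may report more compounds than this note shows. Statements on the series, on what has been measured and on what is new or still open speak of the compounds shown alone.

Working notes on the series around a shared core. Compound 1 `CC(C)C/N=C(\NC#N)Nc1cccnc1` carries isopropyl on the saturated chain carbon bound to the double-bonded nitrogen; in a functional assay on the whole organism (blood, strain Wistar-Okamoto) with Rattus norvegicus as the target, with a stated time of 5 days (on this read-out higher numbers stand for an effect only at larger amounts of compound and lower numbers for an effect already at smaller amounts), compound 1 gives 20 mg/kg. Compound 2 `CCCCCCC/N=C(\NC#N)Nc1cccnc1` has hexyl in place of isopropyl there. In this assay compound 2 reaches only a limit, > 50 mg/kg. That step is an at least 2.5-fold higher number from compound 1 to compound 2 (0.39 log units; beyond the scatter), read with the caveat of the limit of > 50 mg/kg in this assay, at which 1 of the 3 values shown sits. Compound 3 `CC(C)C(/N=C(\NC#N)Nc1cccnc1)C(C)C` adds isopropyl in place of hydrogen on that same carbon, and in this assay compound 3 gives 5 mg/kg, the lowest of the two numbers shown, the step being a 4.0-fold lower number from compound 1 to compound 3 (0.60 log units; beyond the scatter).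

Compound 4 `CC(C)C(/N=C(\NC#N)Nc1ccncc1)C(C)C` differs from compound 3 only in the ring on the amine nitrogen: pyridin-4-yl in place of pyridin-3-yl on an amine nitrogen. Neither measured step touches that ring; both concern the alkyl side, so they give no size or direction for this change, and the step is expected to stay within the scatter: a 1.4-fold higher number from compound 3 to compound 4 (0.15 log units; within the scatter). Compound 4 is therefore estimated at 7 mg/kg, between 2 mg/kg and 30 mg/kg. Within the data shown here, the range is kept wide; no measured step changes the ring.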

Compound 4, minimum effective dose: 8 mg/kg
For compound 4 the middle estimate is 1.1-fold (0.06 log units) below the measured one, and the stated range covers the measured number.
By their numbers in this assay, from the lowest: compounds 3 and 4 (each within the scatter of the next); then compound 1. At a limit, above all of these: compound 2.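

In this assay, among these compounds, pyridin-4-yl in place of pyridin-3-yl on an amine nitrogen is the first measured change on the ring side of the series, and it gives a 1.6-fold higher number from compound 3 to compound 4 (0.20 log units; within the scatter). With the alkyl side of compound 3 held fixed, the two rings cannot be told apart on this read-out, whereas both earlier steps, on the alkyl side, lay beyond the scatter. No measurement shown bears on why the ring change reads this way.

As far as these compounds go, the ring change is seen with the alkyl side of compound 3 only, so whether it stays within the scatter with the alkyl side of compound 1 remains open. Also open, from the compounds shown here alone, is how a phenyl or pyridin-2-yl group on the amine nitrogen would read in this assay.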